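Removing a trifluoromethyl group in two related quinoline series

A few compounds are considered here, and "the series" means these few. Any claim that something is new, unique, unknown or untested is made for them only; others in the source may bear on it.

Measured compounds:
compound 1, `FC(F)(F)c1cccc(/C=C\c2cc3ccccc3nc2Cl)c1`, 6150 nM in an ADME assay on 184B5 cells (Homo sapiens) for antiproliferative activity, read by sulforhodamine B assay, with a stated time of 72 h; on this read-out lower numbers stand for stronger inhibition and higher numbers for weaker inhibition
compound 2, `FC(F)(F)c1cc(/C=C\c2cc3ccccc3nc2Cl)cc(C(F)(F)F)c1`, 13700 nM in this assay
compound 3, `COc1ccc2nc(Cl)c(/C=C\c3ccc(C(F)(F)F)cc3C(F)(F)F)cc2c1`, for which this assay gives only a limit, > 50000 nM

Compounds 1 and 2 share one core; compound 3 carries a core that differs from it, and the difference between the two cores is not broken down here. Compound 3 sits at the upper limit of this assay (the limit of > 50000 nM in this assay, at which 1 of the 3 values shown sits), so its value is a limit and not a number.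

Between the two measured partners, the change is hydrogen in place of trifluoromethyl on an aromatic carbon, and it gave a 2.2-fold lower number from compound 2 to compound 1 (0.35 log units; beyond the scatter).

Compound 4, `COc1ccc2nc(Cl)c(/C=C\c3ccccc3C(F)(F)F)cc2c1`, has not yet been measured. It arises from compound 3 by hydrogen in place of trifluoromethyl on an aromatic carbon. Within the data shown here, this is the same kind of change as the one from compound 2 to compound 1, but not the same: in compound 3 the leaving group sits meta to a trifluoromethyl group and para to a large group, whereas in compound 2 it sits meta to a large group and meta to a trifluoromethyl group.

The step from compound 3 to compound 4 is expected to be about an at least 1.6-fold lower number from compound 3 to compound 4 (0.22 log units; that floor lies within the scatter), a modest change because a 2.2-fold lower number from compound 2 to compound 1 (0.35 log units; beyond the scatter) was seen for the same kind of change. Since compound 3 is known only as a limit, compound 4 may itself return a limit. Compound 4 is estimated at 30000 nM, most likely between 10000 nM and 100000 nM.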

Compound 4, half-maximal inhibitory concentration: 5310 nM
Compound 4: middle estimate off by 5.6-fold (0.75 log units), on the high side, outside the stated range (below it).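

Replacing a trifluoromethyl group with hydrogen gave an at least 9.4-fold lower number from compound 3 to compound 4 (0.97 log units; beyond the scatter) in this assay, so the number fell on both cores, but the size of the fall did not carry over from one core to the other: the same change on two cores in this assay, a 2.2-fold lower number (0.35 log units; beyond the scatter) from compound 2 to compound 1 and an at least 9.4-fold lower number (0.97 log units; beyond the scatter) from compound 3 to compound 4, at least 4.2-fold (0.62 log units) apart, beyond the scatter of two such steps

Compound 3 gives only > 50000 nM, which is a limit of the assay and not a number.

From the compounds shown here alone, for these two pairs, the result shows that the direction of the change was shared while a step measured on one core gave a poor guide to its size on the other, but it does not show what produces the gap, and the full size of the new step remains unknown, as the two pairs differ both in their core and in where the trifluoromethyl group leaves the ring.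

The compounds shown leave open whether the same change would give a small or a large step on a third core, and whether the methoxy group carried by compound 3 and compound 4 has any part in the gap. They also leave open how the activity would respond if a different group took the place of the trifluoromethyl group, such as a nitrile, an amine or a carboxylic acid.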